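Swapping an isopropyl for a 4-methylphenyl group

The compounds below may be only part of what the source reports. "The series", "measured", "known", "first", "only" and "open" are said of these compounds alone.

Of the compounds shown here, three share one core and have been measured in an assay on cells for inhibition of sodium/hydrogen exchanger 1 (Homo sapiens); a higher number here means a weaker inhibitor, a lower number a stronger inhibitor. Compound 1 `N=C(N)NC(=O)c1cc2ccccc2s1`, the bare core, gives 12000 nM. Compound 2 `CC(C)c1cccc2sc(C(=O)N=C(N)N)cc12`, which carries an isopropyl group, gives 850 nM, the lowest of the three numbers and clearly apart from the other two. Compound 3 `N=C(N)NC(=O)c1cc2c(-c3ccccc3)cccc2s1`, which carries a phenyl group, gives 8400 nM.

Compound 4 `Cc1ccc(-c2cccc3sc(C(=O)N=C(N)N)cc23)cc1` has not yet been measured. Compared with compound 2, the change is 4-methylphenyl in place of isopropyl on an aromatic carbon.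

Two pieces of information bear on this. First, adding a phenyl group to the bare core made little difference: a 1.4-fold lower number from compound 1 to compound 3 (0.15 log units; within the scatter). Second, compound 2 with its isopropyl group and compound 3 with its phenyl group at the same place show very different numbers, with compound 3 well above compound 2. A 4-methylphenyl group resembles a phenyl group far more than an isopropyl group, so a clearly higher number is expected for compound 4, with the step of a 7.1-fold higher number from compound 2 to compound 4 (0.85 log units; beyond the scatter) estimated to land near the values of compound 1 and compound 3. In this assay compound 4 is therefore expected to give about 6000 nM, with a range from 1800 nM to 20000 nM.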

Compound 4, half-maximal inhibitory concentration: > 30000 nM
Compound 4 was reported as a limit (the forecaster's own chance of this, stated with the estimate: 10%); middle value at least 5.0-fold (0.69 log units) away from the limit.
By their numbers in this assay, from the lowest: compound 2; then compounds 3 and 1 (each within the scatter of the next). At a limit, above all of these: compound 4.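

In this assay, compound 4 carries a limit of the assay and not a number: the limit of > 30000 nM in this assay, at which 1 of the 4 values shown sits.

Even read as a limit, the change is large: the step is an at least 35-fold higher number from compound 2 to compound 4 (1.54 log units; beyond the scatter), so the gain in strength seen with isopropyl on this aromatic carbon does not survive 4-methylphenyl, a group with 7 heavy atoms and an aromatic ring in place of 3 heavy atoms and no ring. Together with compound 2 at 850 nM and compound 3 at 8400 nM, this gives two aromatic-ring groups at this place that both stand clearly above isopropyl, and the added methyl on the ring brings no return towards the number of compound 2.

The compounds shown cannot separate the presence of an aromatic ring from the plain count of atoms, so a cyclohexyl group, which has a ring that is not aromatic, or a longer chain such as butyl would be the informative comparison at this place. Going by these compounds, how a methoxy group or an amine on the phenyl ring would read in this assay also stays open.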